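This account rests on a few compounds, and the source may have more. Where it says the series, first, only, none or still open, it means among the compounds named here.

In an ADME assay on GES1 cells (Homo sapiens) for inhibition, read by MTT assay, with a stated time of 72 h (a higher number here means a weaker inhibitor, a lower number a stronger inhibitor), three compounds have been measured so far. Compound 1 (`Cc1cc(Nc2cc(-c3ccccc3)[nH]n2)n2nc(SCc3c(Cl)cccc3Cl)nc2n1`) gives 39600 nM there, compound 2 (`Cc1cc(Nc2cc(-c3cccs3)[nH]n2)n2nc(SCc3ccc(Br)cc3)nc2n1`) gives 38700 nM and compound 3 (`Cc1cc(Nc2cc(-c3ccccc3)[nH]n2)n2nc(SCc3ccc(Cl)cc3)nc2n1`) gives 31800 nM on the same read-out. Compound 2 thus stands within the scatter of both others and cannot be ranked against them.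

Compound 4 (`Cc1cc(Nc2cc(-c3ccc(F)cc3)[nH]n2)n2nc(SCc3ccc(Br)cc3)nc2n1`), not yet measured, differs from compound 2 at one place (4-fluorophenyl in place of thiophen-2-yl on an aromatic carbon) with 4-fluorophenyl in place of thiophen-2-yl on an aromatic carbon. Among the measured compounds shown here, the only measured single change is a 1.2-fold lower number from compound 1 to compound 3 (0.10 log units; within the scatter) and it lies within the scatter, but it sits on a saturated chain carbon bound to a sulfur and not at this aromatic carbon, so it bears only indirectly. For the measured compounds named here, no measured pair isolates a change at the aromatic carbon. Compound 2 and compound 3 differ at that carbon as well as on the chain, yet their values stay within the scatter of each other.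

Starting from compound 2 at 38700 nM and with a 1.2-fold lower number from compound 1 to compound 3 (0.10 log units; within the scatter) as the only guide, no step beyond the scatter is expected in this assay in either direction. The expected change is a 1.1-fold lower number from compound 2 to compound 4 (0.03 log units; within the scatter) and would stay within the scatter. For compound 4 the estimated value is 36000 nM with an expected range from 18000 nM to 70000 nM on this read-out.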

Compound 4, half-maximal inhibitory concentration: 34200 nM
Beside the measured number, compound 4's estimate is 1.1-fold (0.02 log units) above it; measured number inside the range.
By their numbers in this assay, from the lowest: compounds 3, 4, 2 and 1 (each within the scatter of the next).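

Among the compounds shown here, the pair compound 2 and compound 4 is the first to isolate a change on this aromatic carbon of the five-membered aromatic ring with 2 nitrogen, and in this assay the exchange of thiophen-2-yl for 4-fluorophenyl gives a 1.1-fold lower number from compound 2 to compound 4 (0.05 log units; within the scatter) and no separation between the two compounds. The entering group has 7 heavy atoms against 5, a six-membered aromatic ring of carbon only in place of a five-membered ring with sulfur, and no hydrogen-bond acceptor against 1, yet none of these differences comes with a step beyond the scatter. Nothing measured on these compounds speaks to why the two groups read alike here.

What the compounds leave open is whether a group of a different kind on this aromatic carbon, such as an amine, a carboxylic acid or a morpholine ring, would give a step beyond the scatter in this assay and not another aromatic ring of similar size. They also leave open whether the exchange of thiophen-2-yl for 4-fluorophenyl would read the same with another group on the sulfur-bound chain carbon.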